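Cytotoxicity on HEL cells: from a chlorophenyl to a naphthyl

The source may hold more compounds than are shown below. What is called first, only, known or untested is meant among the compounds shown, and "the series" means these compounds.

Measured compounds:
compound 1, `CO[C@@H]1[C@@H](OC)[C@H](c2ccccc2)O[C@@H]2CO[C@@H](c3ccc(C)cc3)O[C@@H]12`, "not determined" (no result reported)
compound 2, `CO[C@@H]1[C@@H](OC)[C@H](c2ccccc2)O[C@@H]2CO[C@@H](c3ccc([N+](=O)[O-])cc3)O[C@@H]12`, "not determined" (no result reported)
compound 3, `CO[C@@H]1[C@@H](OC)[C@H](c2ccccc2)O[C@@H]2CO[C@@H](c3cccc(Cl)c3)O[C@@H]12`, >= 40 ug/mL

Three compounds share one core and differ only in the aryl group on the saturated ring carbon between two ring oxygen atoms. In a functional assay on HEL cells (Homo sapiens) for cytotoxicity (a higher number here means that more compound is tolerated, a lower number that less compound is tolerated), compound 1 gives "not determined" (no result reported) and compound 2 gives "not determined" (no result reported), so no number stands behind either. Among the measured compounds shown here, compound 3 is the only one with a reading, and that reading is a limit of the assay rather than a number: in this assay compound 3 gives >= 40 ug/mL. This is the limit of >= 40 ug/mL in this assay, at which 1 of the 3 values shown sits. For the measured compounds named here, nothing among the measured compounds links one aryl group to another, so no step can be sized.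

Compound 4, `CO[C@@H]1[C@@H](OC)[C@H](c2ccccc2)O[C@@H]2CO[C@@H](c3ccc4ccccc4c3)O[C@@H]12`, is the next member. It carries naphthalen-2-yl in place of 3-chlorophenyl on a saturated ring carbon.

Going by the values given here, with no measured step to lean on, the expected step in this assay is none beyond the scatter, toward the same limit. Compound 4 is expected to give 40 ug/mL, within 15 ug/mL to 80 ug/mL. The expected step is a number no higher from compound 3 to compound 4 (the limit leaves the size open).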

Compound 4, minimum cytotoxic concentration: >= 16 ug/mL
Compound 4 gave a limit, no number; the forecaster's own chance of this, stated with the estimate: 65%; the middle value is on the limit's open side.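

In this assay, among the compounds shown here, compound 3 and compound 4 both give limits of the assay rather than numbers, and no step between them can be read. The compounds shown leave open how much of either compound the cells actually tolerate, and whether exchanging 3-chlorophenyl for naphthalen-2-yl changes that at all.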